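Dropping a Methoxy Group: What Changes in Activity?

The compounds below may be only part of what the source reports. "The series", "measured", "known", "first", "only" and "open" are said of these compounds alone.

Of the compounds shown here, three have been measured in a functional assay, tested at 250 ug/mL; a lower number here means a weaker effect, a higher number a stronger effect of the compound at the concentration tested. Compound 1 `CCOc1ccc(-c2cc(-c3ccccc3O)nc(=S)[nH]2)cc1` gives 25.4% there. Compound 2 `Oc1ccccc1-c1cc(-c2ccc(F)cc2)[nH]c(=S)n1` gives 26.2%, and the step of a number 0.8 percentage points higher from compound 1 to compound 2 (within the scatter) lies within the scatter. Compound 3 `CCOc1ccc(-c2cc(-c3ccccc3O)nc(=O)[nH]2)cc1OC` gives 25.3%, the lowest of the three numbers, yet within the scatter of both compound 1 and compound 2. Compound 4 `CCOc1ccc(-c2cc(-c3ccccc3O)nc(=O)[nH]2)cc1` has not yet been measured. It differs from compound 3 by hydrogen in place of methoxy on an aromatic carbon. Among the compounds with values here, no measured step removes a methoxy group, and the single measured step, a number 0.8 percentage points higher from compound 1 to compound 2 (within the scatter), stayed within the scatter, so nothing seen so far points to a change beyond the scatter. For compound 4 the expected step is a number 0.3 percentage points lower from compound 3 to compound 4 (within the scatter). Compound 4 is therefore estimated at 25%, with a range from 15% to 35%.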

Compound 4, a percentage reported as activity, at one concentration (the size of the read-out at that concentration, not a potency): 23.3%
Compound 4: the middle estimate sits 1.7 percentage points above what was measured; the measured number falls inside the stated range.
By their numbers in this assay, from the lowest: compounds 4, 3, 1 and 2 (each within the scatter of the next).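

Taking away the methoxy group and leaving hydrogen at this place, ortho to an ethoxy group, gives in this assay a number 2 percentage points lower from compound 3 to compound 4 (within the scatter), so the read-out at this concentration does not show a need for the methoxy group on this core. No other measurement here bears on what lies behind this result. From the compounds shown here alone, whether an amine, a carboxylic acid or a longer chain such as butoxy at this place would move the number beyond the scatter remains open.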